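The source may report more compounds than this note shows. Statements on the series, on what has been measured and on what is new or still open speak of the compounds shown alone.

Measured in a physicochemical assay for solubility, in phosphate buffer, with a stated time of 24 h, at pH 7.4; a lower number here means a less soluble compound, a higher number a more soluble compound:
- Compound 1 `COc1ccc(-c2ccc(OCc3cc(C(=O)NS(=O)(=O)c4ccccc4)oc3C)cc2)c(C)c1`: 20 ug/mL
- Compound 2 `Cc1oc(C(=O)NS(=O)(=O)c2ccccc2)cc1COc1ccc(-c2ccccc2)cc1`: 2 ug/mL
- Compound 3 `COc1ccc(-c2ccc(OCc3cc(C(=O)NS(=O)(=O)c4ccc(CN)cc4)oc3C)cc2)cc1`: < 0.6 ug/mL (a limit of the assay, not a number)

Compound 3 stands only at a limit, as the limit of < 0.6 ug/mL in this assay, at which 1 of the 3 values shown sits, shows. Compound 4 `COc1ccc(-c2ccc(OCc3cc(C(=O)NS(=O)(=O)c4ccc(C)cn4)oc3C)cc2)cc1` carries 5-methylpyridin-2-yl in place of 4-(aminomethyl)phenyl on a sulfonyl sulfur. Going by the values given here, no measured step touches that place. Among the compounds with values here, the sole measured step, a 10-fold lower number from compound 1 to compound 2 (1.00 log units; beyond the scatter), lies elsewhere in the molecule and shows only how far values can move in this set. The expectation of a rise leans on compound 2, which gives a number, 2 ug/mL. An upward move is expected, with an estimated at least 6.6-fold higher number from compound 3 to compound 4 (0.82 log units; beyond the scatter). Compound 4 is expected to give 4 ug/mL, within an estimated range of 0.6 ug/mL to 30 ug/mL.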

Compound 4, solubility: 5 ug/mL
For compound 4 the middle estimate is 1.3-fold (0.10 log units) below the measured one, within the range that was stated.
By their numbers in this assay, from the lowest: compound 2; then compound 4; then compound 1. At a limit, below all of these: compound 3.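

In this assay, the group on the sulfonyl sulfur now has a step of its own, where the earlier step lay elsewhere in the molecule: 5-methylpyridin-2-yl in place of 4-(aminomethyl)phenyl gives an at least 8.3-fold higher number from compound 3 to compound 4 (0.92 log units; beyond the scatter). Compound 3 stands at a limit of the assay, not a number, and the step is a bound only: the limit of < 0.6 ug/mL in this assay, at which 1 of the 4 values shown sits.

The compounds shown leave open whether the loss of the aminomethyl group or the entry of the ring nitrogen carries this step. A 4-methylphenyl group on the same sulfonyl sulfur would separate the two.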